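The compounds below may be only part of what the source reports. "The series", "measured", "known", "first", "only" and "open" are said of these compounds alone.

Compound 1 `CCNCCn1c(N2CCN(C)CC2)nc2ccccc21` gives 290 nM in a functional assay on ileum for inhibition of histamine H1 receptor (Cavia porcellus); a lower number here means a stronger inhibitor, a higher number a weaker inhibitor. Compound 2 `CCSCCn1c(N2CCN(C)CC2)nc2ccccc21` gives 19 nM in this assay.

Compound 2 holds the lowest of the two numbers in this assay; its nearest neighbour is compound 1, with a 15-fold lower number from compound 1 to compound 2 (1.18 log units; beyond the scatter). Compound 3 `CCCOCCn1c(N2CCN(C)CC2)nc2ccccc21` carries propoxy in place of ethylsulfanyl on a saturated chain carbon, two bonds along the chain from an aromatic nitrogen. Within the data shown here, the one measured step changed ethylamino to ethylsulfanyl at the same chain carbon and was large, but no measured step exchanges a thioether for an ether there, so it bears only loosely on this change. A modest rise in the number is expected: a 2.4-fold higher number from compound 2 to compound 3 (0.37 log units; beyond the scatter). Compound 3 is estimated at 45 nM, within 10 nM to 200 nM.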

Compound 3, half-maximal inhibitory concentration: 20 nM
Estimate against measurement, compound 3: 2.3-fold (0.35 log units) above; measured number inside the range.
By their numbers in this assay, from the lowest: compounds 2 and 3 (each within the scatter of the next); then compound 1.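

In this assay, propoxy in place of ethylsulfanyl on this saturated chain carbon gives a 1.1-fold higher number from compound 2 to compound 3 (0.02 log units; within the scatter), so sulfur is not required here when propoxy takes its place. Propoxy in place of ethylamino gives a 15-fold lower number from compound 1 to compound 3 (1.16 log units; beyond the scatter), which leaves ethylamino as the one group of the three set apart in this series. No measurement shown explains this difference.

Ethoxy would show the exchange of sulfur for oxygen without the change in chain length. As far as these compounds go, a tertiary amine such as dimethylamino at this place remains open as well.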